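The source may report more compounds than this note shows. Statements on the series, on what has been measured and on what is new or still open speak of the compounds shown alone.

Going by the values given here, compound 1 `CC/C(=C(/c1ccc(/C=C/C(=O)O)cc1)c1cc2ccccc2[nH]1)c1ccccc1C(F)(F)F` holds the lowest of the three numbers measured so far: in a functional assay on MCF7 cells (Homo sapiens) for inhibition (a higher number here means a weaker inhibitor, a lower number a stronger inhibitor), compound 1 gives 8 nM. Its two companions share the core and differ from it only in the aryl group on the double-bonded chain carbon. Compound 2 `CC/C(=C(/c1ccc(/C=C/C(=O)O)cc1)c1cc2ccccc2[nH]1)c1ccc(C(F)(F)F)cc1` gives 139 nM in this assay, and compound 3 `CC/C(=C(/c1ccc(/C=C/C(=O)O)cc1)c1cc2ccccc2[nH]1)c1ccc(OC)cc1` gives 61 nM. The step of a 17-fold higher number from compound 1 to compound 2 (1.24 log units; beyond the scatter) is the larger move away from compound 1, the step of a 7.6-fold higher number from compound 1 to compound 3 (0.88 log units; beyond the scatter) the smaller, and between the two the step of a 2.3-fold lower number from compound 2 to compound 3 (0.36 log units; beyond the scatter) is modest.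

Compound 4 `CC/C(=C(/c1ccc(/C=C/C(=O)O)cc1)c1cc2ccccc2[nH]1)c1ccc(F)cc1Cl` is the next step from compound 1: 2-chloro-4-fluorophenyl in place of 2-(trifluoromethyl)phenyl on a double-bonded chain carbon bound to a double-bonded chain carbon and a saturated chain carbon. Both measured steps from compound 1 bear on it, and both gave higher numbers when the 2-(trifluoromethyl)phenyl was exchanged for 4-(trifluoromethyl)phenyl or for 4-methoxyphenyl. The 2-chloro-4-fluorophenyl of compound 4, by contrast, shares the first part of its name with the 2-(trifluoromethyl)phenyl of compound 1 and the second part with the 4-(trifluoromethyl)phenyl of compound 2 and the 4-methoxyphenyl of compound 3. Compound 4 is therefore expected to sit closer to compound 1 than compounds 2 and 3 do, with a step of about a 1.9-fold higher number from compound 1 to compound 4 (0.27 log units; within the scatter) toward a higher number, near the edge of the scatter. The estimate for compound 4 in this assay is 15 nM, within a range from 5 nM to 50 nM.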

Compound 4, half-maximal inhibitory concentration: 39 nM
The estimate for compound 4 lay 2.6-fold (0.41 log units) below the measured number, within the range that was stated.
By their numbers in this assay, from the lowest: compound 1; then compounds 4 and 3 (each within the scatter of the next); then compound 2.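

In this assay, all three exchanges of the 2-(trifluoromethyl)phenyl shown so far give higher numbers, and the 2-chloro-4-fluorophenyl is no exception: the step of a 4.9-fold higher number from compound 1 to compound 4 (0.69 log units; beyond the scatter) lies beyond the scatter, so carrying a group in the 2-position of the phenyl ring does not by itself retain the number of compound 1. The new group also separates from one of the earlier aryl groups but not from the other, with the step of a 3.6-fold lower number from compound 2 to compound 4 (0.55 log units; beyond the scatter) beyond the scatter, while the step of a 1.6-fold lower number from compound 3 to compound 4 (0.19 log units; within the scatter) within the scatter leaves the 2-chloro-4-fluorophenyl and the 4-methoxyphenyl indistinguishable in this read-out. Nothing available here accounts for these differences.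

The compounds shown change two things at once on going from compound 1 to compound 4, both the group at the 2-position and the presence of a group at the 4-position, so a 2-chlorophenyl or a 2-methoxyphenyl at this place would be needed to tell those apart. They also leave open whether the low number of compound 1 would survive with an amide in place of the carboxylic acid.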